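This account rests on a few compounds, and the source may have more. Where it says the series, first, only, none or still open, it means among the compounds named here.

In a functional assay on MCF7 cells (Homo sapiens) for antiproliferative activity, read by sulforhodamine B assay, with a stated time of 72 h (a higher number here means a weaker inhibitor, a lower number a stronger inhibitor), three compounds have been measured. Compound 1 `FC(F)(F)c1ccc(/C=C\c2cc3ccccc3nc2Cl)cc1` gives 4260 nM, compound 2 `COc1ccc2nc(Cl)c(/C=C\c3ccc(C(F)(F)F)cc3)cc2c1` gives 12400 nM, and compound 3 `FC(F)(F)c1ccc(/C=C\c2cc3ccccc3nc2Cl)c(C(F)(F)F)c1` gives 10500 nM. Compound 3 and compound 2 lie within the scatter of each other, and both carry higher numbers than compound 1.

Compound 4 `COc1ccc2nc(Cl)c(/C=C\c3ccc(C(F)(F)F)cc3C(F)(F)F)cc2c1` has not yet been measured. It differs from compound 3 in one place: methoxy in place of hydrogen on an aromatic carbon. This is methoxy in place of hydrogen on an aromatic carbon.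

The same replacement occurs once among the measured compounds and gives a 2.9-fold higher number from compound 1 to compound 2 (0.46 log units; beyond the scatter), a modest step beyond the scatter. The other measured step, a 2.5-fold higher number from compound 1 to compound 3 (0.39 log units; beyond the scatter), is also modest and beyond the scatter. It is the trifluoromethyl in place of hydrogen on an aromatic carbon, which compound 3 already carries, so compound 4 holds both replacements together. For the measured compounds named here, no measured compound shows whether two such steps add up in full. Going by the values given here, a modest rise in the number is therefore expected, close in size to the single methoxy step but somewhat smaller. The expected step is a 2.4-fold higher number from compound 3 to compound 4 (0.38 log units; beyond the scatter). Compound 4 is estimated at 25000 nM, with an expected range of 10000 nM to 60000 nM.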

Compound 4, half-maximal inhibitory concentration: > 50000 nM
Compound 4: only a limit was reported (the forecaster's own chance of this, stated with the estimate: 15%); at least 2.0-fold (0.30 log units) between middle value and limit.
By their numbers in this assay, from the lowest: compound 1; then compounds 3 and 2 (each within the scatter of the next). At a limit, above all of these: compound 4.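

In this assay, methoxy on an aromatic carbon, meta to a fused ring and para to a fused ring, raises the number on the core of compound 3 as well, giving an at least 4.7-fold higher number from compound 3 to compound 4 (0.67 log units; beyond the scatter) on a reading that rests on a limit and not on a number. The trifluoromethyl replacement likewise raises the number on the methoxy-bearing core, giving an at least 4.0-fold higher number from compound 2 to compound 4 (0.60 log units; beyond the scatter) on the same limit, and whether it does so to a different extent than before stays undecided: the same change on two cores in this assay, a 2.5-fold higher number (0.39 log units; beyond the scatter) from compound 1 to compound 3 and an at least 4.0-fold higher number (0.60 log units; beyond the scatter) from compound 2 to compound 4; the limit leaves it open whether they differ. The same is true of the methoxy replacement, so each change now raises the number on two cores, with no compound shown going against this, but the two steps of neither change can be ranked: the same change on two cores in this assay, a 2.9-fold higher number (0.46 log units; beyond the scatter) from compound 1 to compound 2 and an at least 4.7-fold higher number (0.67 log units; beyond the scatter) from compound 3 to compound 4; the limit leaves it open whether they differ.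

The compounds shown leave open the actual value of compound 4, which is given only as a limit, and with it the full size of both new steps. They also leave open whether a hydroxyl or an amine in place of methoxy at this position would raise the number as methoxy does.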